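The source may hold more compounds than are shown below. What is called first, only, known or untested is meant among the compounds shown, and "the series" means these compounds.

In a functional assay (aorta) with Rattus norvegicus as the target (on this read-out lower numbers stand for stronger inhibition and higher numbers for weaker inhibition), three compounds have been measured that share one core and differ only in the group on a saturated chain carbon, three bonds along the chain from an oxygen on an aromatic ring. Compound 1 `CC(C)c1cn2ccccc2c1S(=O)(=O)c1ccc(OCCCN2CCN(c3ccccc3)CC2)cc1` gives 205 nM, compound 2 `COc1ccc(CNCCCOc2ccc(S(=O)(=O)c3c(C(C)C)cn4ccccc34)cc2)cc1OC` gives 13 nM, and compound 3 `CCN(CC)CCCOc1ccc(S(=O)(=O)c2c(C(C)C)cn3ccccc23)cc1` gives 228 nM. Compound 3 therefore sits level with compound 1, since a 1.1-fold higher number from compound 1 to compound 3 (0.05 log units; within the scatter) does not separate them, while an 18-fold higher number from compound 2 to compound 3 (1.24 log units; beyond the scatter) sets it well apart from compound 2.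

The next compound is compound 4 `CCCCN(CCCC)CCCOc1ccc(S(=O)(=O)c2c(C(C)C)cn3ccccc23)cc1`, which carries dibutylamino in place of diethylamino at that same place: dibutylamino in place of diethylamino on a saturated chain carbon, three bonds along the chain from an oxygen on an aromatic ring. For the measured compounds named here, no measured step alters only the alkyl chains on this nitrogen, so the evidence is indirect. Two steps show what this place can do in this assay. Compound 2 shows a large change, a 16-fold lower number from compound 1 to compound 2 (1.20 log units; beyond the scatter), whereas compound 3 shows none beyond the scatter, a 1.1-fold higher number from compound 1 to compound 3 (0.05 log units; within the scatter). With both outcomes on record, a modest shift is the cautious expectation, and a lower number is the more likely direction, though the data do not settle this. The expected change is a 2.3-fold lower number from compound 3 to compound 4 (0.36 log units; beyond the scatter). For compound 4 the estimated value is 100 nM, with an expected range of 30 nM to 300 nM.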

Compound 4, half-maximal inhibitory concentration: 21.6 nM
Beside the measured number, compound 4's estimate is 4.6-fold (0.67 log units) above it; the measured number lies below the stated range.
By their numbers in this assay, from the lowest: compounds 2 and 4 (each within the scatter of the next); then compounds 1 and 3 (each within the scatter of the next).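

In this assay, the alkyl chains on this nitrogen prove to matter on their own, with an 11-fold lower number from compound 3 to compound 4 (1.02 log units; beyond the scatter) for dibutylamino in place of diethylamino, whereas the earlier compounds had shown a large step at this place only with the (3,4-dimethoxybenzyl)amino group of compound 2. That group's aromatic ring is therefore not required for a low number in this series: dibutylamino has no ring, yet a 1.7-fold higher number from compound 2 to compound 4 (0.22 log units; within the scatter) leaves the two compounds inside the scatter of each other, while a 9.5-fold lower number from compound 1 to compound 4 (0.98 log units; beyond the scatter) separates compound 4 from the 4-phenylpiperazin-1-yl compound as well. The data on hand offer no explanation for the size of these steps.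

The compounds shown leave open how the number runs with chain length on this nitrogen, both between and beyond these two groups, as with dipropylamino or dipentylamino. They also leave open whether an unsymmetrical amine such as N-butyl-N-ethylamino, or a cyclic amine such as piperidin-1-yl, would stay level with compound 4 or fall back towards compound 3.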